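This account rests on a few compounds, and the source may have more. Where it says the series, first, only, none or still open, it means among the compounds named here.

Three compounds built on closely related cores were examined in a functional assay on EKVX cells (Homo sapiens) for cytotoxicity, read by sulforhodamine B assay, with a stated time of 48 h; on this read-out higher numbers stand for lower toxicity in this test and lower numbers for higher toxicity in this test. Compound 1 `Nc1nc(Cl)c2ncn(Cc3ccc(CCl)cc3)c2n1` gave 28200 nM in this assay. Compound 2 `ClCc1cccc(Cn2cnc3c(Cl)nc(Cl)nc32)c1` gave 6450 nM in this assay, the lowest of the three numbers, and compound 3 `ClCc1ccc(Cn2cnc3c(Cl)nc(Cl)nc32)cc1` gave 58900 nM in this assay. The difference between the cores of compound 2 and compound 3, which share the same atoms joined differently, is not broken down here; the two values show compound 2 sitting well below compound 3.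

One structural change can be followed between measured compounds: amino in place of chloro on an aromatic carbon. In this assay it produced a step of a 2.1-fold lower number from compound 3 to compound 1 (0.32 log units; beyond the scatter), a modest lowering of the number that lies beyond the usual scatter.

Compound 4 `Nc1nc(Cl)c2ncn(Cc3cccc(CCl)c3)c2n1` has not yet been measured. It relates to compound 2 by the same change, (amino in place of chloro on an aromatic carbon), made at a place described in exactly the same words as the change from compound 3 to compound 1. The expectation for compound 4 therefore rests on a single precedent: because the step of a 2.1-fold lower number from compound 3 to compound 1 (0.32 log units; beyond the scatter) was modest and toward a lower number, a step of similar size is expected from compound 2 to compound 4, namely a 2.1-fold lower number from compound 2 to compound 4 (0.32 log units; beyond the scatter). On that basis compound 4 is estimated to give about 3100 nM in this assay. Allowing for the scatter of such measurements and for only one precedent, compound 4 is expected to fall somewhere between 1200 nM and 8000 nM in this assay.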

Compound 4, concentration lethal to 50% of the cells: 60300 nM
Compound 4: the middle estimate sits 19-fold (1.29 log units) below what was measured, outside the stated range (above it).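

Placed in for chloro on an aromatic carbon between two ring nitrogen atoms, amino brought a 9.3-fold higher number from compound 2 to compound 4 (0.97 log units; beyond the scatter) in this assay, a shift toward lower toxicity in this test. Set beside the earlier step, this shows that the change did not carry from one core to the other, either in size or in direction: the same change on two cores in this assay, a 2.1-fold lower number (0.32 log units; beyond the scatter) from compound 3 to compound 1 and a 9.3-fold higher number (0.97 log units; beyond the scatter) from compound 2 to compound 4, 20-fold (1.29 log units) apart, beyond the scatter of two such steps. Among the compounds shown here, what it does not show is which feature of the two cores, which share the same atoms joined differently, sets the steps apart, and with only two pairs it cannot say how the same change would behave on any further core.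

The compounds shown leave open how other groups at that same carbon, such as a methylamino group, a methoxy group or a hydroxyl group, would compare with amino and chloro on each of the two cores. They also leave open what part the chloromethyl group plays, as all four compounds carry it, and whether a hydroxymethyl or a plain methyl group in its place would preserve the split between the two cores.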